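Compound 4: pyrazolyl in place of the substituted oxazolyl

The source may report more compounds than this note shows. Statements on the series, on what has been measured and on what is new or still open speak of the compounds shown alone.

The shared core carries an ethylcarbamoyl group and a variable five-membered arm. Compound 2 `CCNCc1cc(-c2c(C(=O)NCC)noc2-c2cc(C(C)C)c(O)cc2O)on1` and compound 3 `CCNC(=O)c1noc(-c2cc(C(C)C)c(O)cc2O)c1-c1cc(CN(CC)CC)no1` were measured in a functional assay on A2780 cells (Homo sapiens) for inhibition; a lower number here means a stronger inhibitor, a higher number a weaker inhibitor; compound 2 gives 45 nM and compound 3 gives 78 nM. Compound 1 `CCNC(=O)c1noc(-c2cc(C(C)C)c(O)cc2O)c1-c1cc(COCC(N)=O)no1` has "not determined" (no result reported) in this assay. Compound 2 and compound 3 sit within the scatter of each other, the step being a 1.7-fold higher number from compound 2 to compound 3 (0.24 log units; within the scatter). Compound 4 `CCNC(=O)c1noc(-c2cc(C(C)C)c(O)cc2O)c1-c1cn[nH]c1` differs from compound 2 by 1H-pyrazol-4-yl in place of 3-((ethylamino)methyl)-1,2-oxazol-5-yl on an aromatic carbon. Going by the values given here, only the step from compound 2 to compound 3 bears on this, and it shows that ethyl on the amine nitrogen changes little; exchanging the whole arm is a larger change without direct precedent here. A modest weakening is expected, a 3.3-fold higher number from compound 2 to compound 4 (0.52 log units; beyond the scatter). Compound 4 is estimated at 150 nM, within 40 nM to 600 nM.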

Compound 4, half-maximal inhibitory concentration: 38 nM
Estimate against measurement, compound 4: 3.9-fold (0.60 log units) above, and the stated range ends above it.
By their numbers in this assay, from the lowest: compounds 4, 2 and 3 (each within the scatter of the next, the first and the last beyond it).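

In this assay, replacing 3-((ethylamino)methyl)-1,2-oxazol-5-yl with 1H-pyrazol-4-yl gives a 1.2-fold lower number from compound 2 to compound 4 (0.07 log units; within the scatter). The earlier step varied only the amine nitrogen, whereas this one shows that the whole arm can be exchanged for a smaller ring, with no amine side chain, without a change beyond the scatter. No supporting data bear on why this position tolerates the exchange. Still open, going by these compounds, is whether a pyrazolyl carrying an aminomethyl chain or a carboxylic acid would stay within the same range.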